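The source may report more compounds than this note shows. Statements on the series, on what has been measured and on what is new or still open speak of the compounds shown alone.

Measured in a functional assay on K562 cells (Homo sapiens) for cytotoxicity, read by MTT assay, with a stated time of 3 days; a lower number here means a stronger inhibitor, a higher number a weaker inhibitor:
compound 1 `N#Cc1c(Nc2ccccn2)nc(SCc2nc3ccccc3[nH]2)nc1-c1ccccc1`: 7 nM
compound 2 `N#Cc1c(NNC(N)=S)nc(SCc2nc3ccccc3[nH]2)nc1-c1ccccc1`: 8.9 nM

Among the measured compounds shown here, compound 2 stands within the scatter of compound 1, the only other measured compound, so the two values mark a single level. In compound 3 `CN1CCN(c2nc(SCc3nc4ccccc4[nH]3)nc(-c3ccccc3)c2C#N)CC1`, 4-methylpiperazin-1-yl enters on the aromatic carbon ortho to a cyano group: a group of 7 heavy atoms (5 carbon, 2 nitrogen; one six-membered non-aromatic ring with 2 hetero atoms) in place of a group of 5 heavy atoms (1 carbon, 3 nitrogen, 1 sulfur; no ring), on an aromatic carbon. For the measured compounds named here, one measured step bears on this, a 1.3-fold higher number from compound 1 to compound 2 (0.10 log units; within the scatter). Going by the values given here, that step changed only the group on a nitrogen on an aromatic ring, and no measured compound carries a non-aromatic ring at this place. With a single small step as a guide, no shift beyond the scatter is expected, though the uncertainty is wide. The expected step is a 1.3-fold higher number from compound 2 to compound 3 (0.13 log units; within the scatter). For compound 3 the estimated value in this assay is 12 nM, with an expected range from 3 nM to 50 nM.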

Compound 3, half-maximal inhibitory concentration: 2.4 nM
Compound 3: the middle estimate sits 5.0-fold (0.70 log units) above what was measured; the whole stated range lies above it.
By their numbers in this assay, from the lowest: compound 3; then compounds 1 and 2 (each within the scatter of the next).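

In this assay, 4-methylpiperazin-1-yl on the aromatic carbon ortho to a cyano group gives a 3.7-fold lower number from compound 2 to compound 3 (0.57 log units; beyond the scatter), and measured against the (pyridin-2-yl)amino group it gives a 2.9-fold lower number from compound 1 to compound 3 (0.46 log units; beyond the scatter). The earlier pair left this place looking indifferent to the group it carries, whereas these steps show that the number can move beyond the scatter when a non-aromatic ring enters, making compound 3 the strongest of the three, though only modestly. No measurement at hand explains the shift.

Going by these compounds, whether the change rests on the ring as such or on its methyl group stays open. An unsubstituted piperazin-1-yl, a morpholin-4-yl or an open-chain dimethylamino group at this carbon would separate these readings, and the compounds shown do not settle how far the trend extends.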